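This account rests on a few compounds, and the source may have more. Where it says the series, first, only, none or still open, it means among the compounds named here.

Measured compounds in a functional assay on MCF7 cells (Homo sapiens) for cytotoxicity, read by MTT assay, with a stated time of 72 h; on this read-out higher numbers stand for weaker inhibition and lower numbers for stronger inhibition:
compound 1 `COc1ccc(/C(=C(/CCN)c2ccccc2)c2ccccc2)cc1` gives 16900 nM
compound 2 `COc1ccc(/C(=C(/CCNC(=O)NC2CCCCC2)c2ccccc2)c2ccccc2)cc1` gives 37200 nM

Among the measured compounds shown here, compound 2 stands at the higher of the two numbers: a 2.2-fold higher number from compound 1 to compound 2 (0.34 log units; beyond the scatter), a modest step beyond the scatter, separates it from compound 1, the only other measured compound. Compound 3 `CCN(CC)C(=O)NCC/C(=C(\c1ccccc1)c1ccc(OC)cc1)c1ccccc1` has not yet been measured in this assay. It differs from compound 2 by diethylamino in place of cyclohexylamino on a carbonyl carbon, so the urea is kept and only the substituent on its far nitrogen is exchanged.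

For the measured compounds named here, no measured step swaps one urea substituent for another. Going by the values given here, the only step that bears on this region at all is the one from compound 1 to compound 2, in which a cyclohexylcarbamoyl group replaced hydrogen on the amine nitrogen and the number rose modestly. That step shows that carrying a urea on this chain is tolerated with a modest loss, but it says nothing about the difference between a cyclohexylamino and a diethylamino group on the carbonyl carbon. Compound 3 is therefore expected to sit close to compound 2, with a 1.2-fold lower number from compound 2 to compound 3 (0.09 log units; within the scatter), a step not expected to exceed the scatter, and its estimated value is 30000 nM, in a range from 12000 nM to 75000 nM.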

Compound 3, half-maximal inhibitory concentration: > 50000 nM
Compound 3: only a limit was reported (the forecaster's own chance of this, stated with the estimate: 10%); at least 1.6-fold (0.22 log units) between middle value and limit.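

Compound 3 is reported in this assay only as a limit, and that limit bounds what can be read of this change: the limit of > 50000 nM in this assay, at which 1 of the 3 values shown sits. The compounds now include a direct exchange of one urea substituent for another on the carbonyl carbon, and diethylamino in place of cyclohexylamino gives an at least 1.3-fold higher number from compound 2 to compound 3 (0.12 log units; that floor lies within the scatter); since that floor lies within the scatter, the exchange cannot be called a loss, although the true gap may be wider. The comparison with the free amine is firmer, as diethylcarbamoyl in place of hydrogen on the amine nitrogen gives an at least 2.9-fold higher number from compound 1 to compound 3 (0.47 log units; beyond the scatter), so both ureas shown give higher numbers than the free amine.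

On these data alone, how far the true number of compound 3 lies past its limit remains open, and with it the real size of the exchange from cyclohexylamino to diethylamino. Also open, as far as these compounds go, is how other groups on the carbonyl carbon, such as dimethylamino, piperidin-1-yl or anilino, would read on this chain, and whether a urea on a longer chain would behave in the same way.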